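This account rests on a few compounds, and the source may have more. Where it says the series, first, only, none or still open, it means among the compounds named here.

Compound 1 `O=C(O)COc1ccc(-c2coc3cc(OCC(=O)O)ccc3c2=O)cc1`: >> 9000 nM
Compound 2 `CCCCC(Oc1ccc2c(=O)c(-c3ccc(O)cc3)coc2c1)C(=O)OCC`: 4500 nM
Compound 3 `O=C(O)CCCCCCOc1ccc2c(=O)c(-c3ccc(O)cc3)coc2c1`: 50 nM

In an assay (Cricetulus griseus) for inhibition of aldehyde dehydrogenase, mitochondrial (Homo sapiens) (a lower number here means a stronger inhibitor, a higher number a weaker inhibitor), compound 1 gives only a limit of the assay rather than a number: the limit of >> 9000 nM in this assay, at which 1 of the 3 values shown sits. Of the two numbers that were obtained, compound 3 holds the lower one and compound 2 the higher, a gap well beyond the scatter. Compound 4 `CCCCCCOc1ccc2c(=O)c(-c3ccc(O)cc3)coc2c1` has not yet been measured in this assay. It differs from compound 3 in one place: hydrogen in place of carboxy on a saturated chain carbon, six bonds along the chain from an oxygen on an aromatic ring. Within the data shown here, no measured pair shows this change on its own, so its size must be guessed. Because compound 3 gives 50 nM with the carboxy in place, and compound 2, which lacks a free acid on its chain, gives 4500 nM, a loss of potency is expected; the expected step is a 30-fold higher number from compound 3 to compound 4 (1.48 log units; beyond the scatter), beyond the scatter. Compound 4 is estimated at 1500 nM, with a range from 300 nM to 8000 nM.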

Compound 4, half-maximal inhibitory concentration: 1500 nM
Beside the measured number, compound 4's estimate shows no gap at the digits printed, and the stated range covers the measured number.
By their numbers in this assay, from the lowest: compound 3; then compound 4; then compound 2. At a limit, above all of these: compound 1.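

In this assay, the change from carboxy to hydrogen on a saturated chain carbon, six bonds along the chain from an oxygen on an aromatic ring, can now be read on its own: it gives a 30-fold higher number from compound 3 to compound 4 (1.48 log units; beyond the scatter), a large step at this position. Compound 4 still gives a number without the carboxy, not a limit. Nothing measured here gives a cause for this step.

The compounds shown leave open whether an amine or an amide in place of the carboxy would match compound 3, and what a longer chain carrying the carboxylic acid would give.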